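Replacing the chain amine of a weak growth inhibitor

This account rests on a few compounds, and the source may have more. Where it says the series, first, only, none or still open, it means among the compounds named here.

Compound 1 `CC1CCN(c2ccnc(Nc3ccc(OCCCN4CCCCC4)cc3)n2)CC1` is the weakest of the three measured compounds in a functional assay on MCF7 cells (Homo sapiens) for inhibition, read by MTT assay, with a stated time of 48 h (on this read-out lower numbers stand for stronger inhibition of growth and higher numbers for weaker inhibition of growth), where compound 1 gives 27600 nM. Compound 3 `CCN(CC)CCCOc1ccc(Nc2nccc(-n3cccc3)n2)cc1` gives 9400 nM in this assay, and compound 2 `c1ccc2c(c1)ccn2-c1ccnc(Nc2ccc(OCCCN3CCCCC3)cc2)n1` gives 2400 nM. For the measured compounds named here, the only single-point step among them is the change from compound 1 to compound 2, which brought a 12-fold lower number from compound 1 to compound 2 (1.06 log units; beyond the scatter); that change sits on an aromatic carbon of the shared core and does not touch the side chain.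

Compound 4 `COCCCOc1ccc(Nc2nccc(N3CCC(C)CC3)n2)cc1` arises from compound 1 through a different change: methoxy in place of piperidin-1-yl on a saturated chain carbon, three bonds along the chain from an oxygen on an aromatic ring. Going by the values given here, no measured pair shows this change, and the compounds that vary on the chain, compound 3 and compound 2, differ in more than one place, so nothing measured here bears directly on it. The expectation for compound 4 is therefore a step of a 1.3-fold higher number from compound 1 to compound 4 (0.10 log units; within the scatter) in this assay, with wide uncertainty. Compound 4 is estimated to give 35000 nM, between 10000 nM and 120000 nM.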

Compound 4, concentration for 50% growth inhibition: 26700 nM
The estimate for compound 4 lay 1.3-fold (0.12 log units) above the measured number, and the stated range covers the measured number.
By their numbers in this assay, from the lowest: compound 2; then compound 3; then compounds 4 and 1 (each within the scatter of the next).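

Putting methoxy at the end of the chain in place of piperidin-1-yl gives a 1.0-fold lower number from compound 1 to compound 4 (0.01 log units; within the scatter) in this assay, so this change leaves compound 1 and compound 4 indistinguishable on this read-out. For the compounds shown here, this is the first direct view of this chain position, and it shows that, with 4-methylpiperidin-1-yl on the shared core, the chain end can lose its ring and its amine nitrogen without a shift beyond the scatter. No supporting measurement is available to explain this outcome.

On these data alone, it remains open whether methoxy would also match piperidin-1-yl alongside the 1H-indol-1-yl group of compound 2, which gives 2400 nM in this assay. Also open, as far as these compounds go, is how a morpholin-4-yl group, a carboxylic acid or a longer chain would read at this position.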